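Swapping a Butyl Chain for a Hydroxyphenyl Ring

The source may hold more compounds than are shown below. What is called first, only, known or untested is meant among the compounds shown, and "the series" means these compounds.

Compound 1 `CCCCNc1nc(-c2ccccc2)c(Cc2c(O)ccc3ccccc23)c(=O)[nH]1` carries a butyl group on a nitrogen on an aromatic ring of the shared core. In a functional assay on RT-112 cells (Homo sapiens) for antiproliferative activity, read by MTT assay, with a stated time of 24 h (on this read-out lower numbers stand for stronger inhibition and higher numbers for weaker inhibition), compound 1 gives 1600 nM, the lowest number among the three measured compounds. Compound 2 `C#CCNc1nc(-c2ccccc2)c(Cc2c(O)ccc3ccccc23)c(=O)[nH]1` gives 130000 nM, and compound 3 `COc1ccc(Nc2nc(-c3ccccc3)c(Cc3c(O)ccc4ccccc34)c(=O)[nH]2)cc1` gives 138000 nM. Both steps away from compound 1 are large: an 81-fold higher number from compound 1 to compound 2 (1.91 log units; beyond the scatter) and an 86-fold higher number from compound 1 to compound 3 (1.94 log units; beyond the scatter), while the two weaker compounds sit close together, with a 1.1-fold higher number from compound 2 to compound 3 (0.03 log units; within the scatter).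

Compound 4 `O=c1[nH]c(Nc2ccc(O)cc2)nc(-c2ccccc2)c1Cc1c(O)ccc2ccccc12` has not yet been measured. It differs from compound 1 in one place: 4-hydroxyphenyl in place of butyl on a nitrogen on an aromatic ring. The closest guide is compound 3, where a 4-methoxyphenyl group on a nitrogen on an aromatic ring brought an 86-fold higher number from compound 1 to compound 3 (1.94 log units; beyond the scatter); compound 4 carries a 4-hydroxyphenyl ring on that nitrogen, so a similarly large step toward weaker inhibition is expected. Compound 4 is therefore estimated at 100000 nM, with a likely range from 20000 nM to 400000 nM. This estimate corresponds to an expected step of a 63-fold higher number from compound 1 to compound 4 (1.80 log units; beyond the scatter) in this assay.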

Compound 4, half-maximal inhibitory concentration: 265000 nM
For compound 4 the middle estimate is 2.7-fold (0.42 log units) below the measured one; the measured number falls inside the stated range.
By their numbers in this assay, from the lowest: compound 1; then compounds 2, 3 and 4 (each within the scatter of the next, the first and the last beyond it).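

In this assay, putting a 4-hydroxyphenyl ring in place of butyl on this nitrogen gives a 170-fold higher number from compound 1 to compound 4 (2.22 log units; beyond the scatter) and, like the 4-methoxyphenyl ring of compound 3, leaves the compound far weaker than compound 1. Changing the methyl on the ring oxygen to hydrogen gives a 1.9-fold higher number from compound 3 to compound 4 (0.28 log units; within the scatter) and so makes no readable difference, which means that the hydrogen-bond donor of the 4-hydroxyphenyl ring does not bring back the inhibition seen with butyl. Compared with the propargyl group, the same ring gives a 2.0-fold higher number from compound 2 to compound 4 (0.31 log units; beyond the scatter) and is a modest step toward weaker inhibition, so among these four compounds only the butyl compound stands clearly apart.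

No measured evidence here explains why butyl stands apart from the other three groups. Going by these compounds, it remains open whether a longer chain, a branched chain such as isobutyl, or a butyl chain ending in an amine or a carboxylic acid would match or improve on compound 1.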